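From phenyl to 4-chlorophenyl at compound 4

A few compounds are considered here, and "the series" means these few. Any claim that something is new, unique, unknown or untested is made for them only; others in the source may bear on it.

Compound 1 `C/C(=N\O)c1ccc(NC(=O)Cn2nc(-c3ccc(Cl)cc3)nc2N)cc1`: 27.4%
Compound 2 `COc1ccc(-c2nc3sc(-c4ccccc4)cn3n2)cc1`: 32%
Compound 3 `C/C(=N/O)c1ccc(NC(=O)Cn2nc(-c3ccccc3)nc2N)cc1`: 15.2%

In a functional assay on SK-OV-3 cells (Homo sapiens) for inhibition, read by sulforhodamine B assay, with a stated time of 48 h, tested at 10 uM (a higher number here means more inhibition of growth at the concentration tested, a lower number less inhibition of growth), compound 2 stands within the scatter of compound 1 and clearly above compound 3. Compound 4 `COc1ccc(-c2nc3sc(-c4ccc(Cl)cc4)cn3n2)cc1` departs from compound 2 by one change: chloro in place of hydrogen on an aromatic carbon. This places chloro in place of hydrogen on an aromatic carbon, para to a large group, turning phenyl into 4-chlorophenyl. Among the compounds with values here, no measured pair isolates this change, so the data give no direct guide to its size. A small rise, or no change beyond the scatter, is therefore expected. The estimated step is a number 3 percentage points higher from compound 2 to compound 4 (within the scatter). For compound 4 the expected value is 35%, within an estimated range of 20% to 52%.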

Compound 4, percent growth inhibition at one concentration: 50.6%
Compound 4: middle estimate off by 15.6 percentage points, on the low side; the range from low to high includes it.
By their numbers in this assay, from the lowest: compound 3; then compounds 1 and 2 (each within the scatter of the next); then compound 4.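

In this assay, within the data shown here, chloro in place of hydrogen on an aromatic carbon, para to a large group, gives the first measured step at this position: a number 18.6 percentage points higher from compound 2 to compound 4 (beyond the scatter). Turning phenyl into 4-chlorophenyl on this core therefore moves growth inhibition upward beyond the scatter, so this position responds to a single added chlorine. Nothing measured here gives a reason for the rise. As far as these compounds go, whether bromo, an amine or a carboxylic acid in the same place would raise the number remains open. Also open, from the compounds shown here alone, is whether the rise depends on the methoxy group that compound 2 and compound 4 share.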